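A few compounds are considered here, and "the series" means these few. Any claim that something is new, unique, unknown or untested is made for them only; others in the source may bear on it.

Series notes. Compound 3 `Cc1n[nH]cc1Nc1nc(N)c2c(C#N)c(N3CCC[C@H]3C)n(C)c2n1` in an assay on isolated protein for inhibition of Leucine-rich repeat serine/threonine-protein kinase 2 (Homo sapiens), read by TR-FRET and LanthaScreen, with stated times of 50 min and 30 min, in the presence of a further agent that is not named here (a lower number here means a stronger inhibitor, a higher number a weaker inhibitor), gives 42 nM. Compound 1 `Cc1nn(C2COC2)cc1Nc1nc(N)c2c(C#N)c(N3CCC[C@H]3C)n(C)c2n1` gives 38 nM and compound 2 `Cc1nn(CC(C)(C)O)cc1Nc1nc(N)c2c(C#N)c(N3CCC[C@H]3C)n(C)c2n1` gives 49 nM; compound 3 thus sits among three numbers that all lie within the usual scatter of one another, so no order among them is claimed. The step to compound 4 `Cc1nn(CC2(O)COC2)cc1Nc1nc(N)c2c(C#N)c(N3CCC[C@H]3C)n(C)c2n1` is (3-hydroxyoxetan-3-yl)methyl in place of hydrogen on an aromatic nitrogen. Within the data shown here, two measured steps bear on it, both changing the group on the same aromatic nitrogen: a 1.1-fold higher number from compound 1 to compound 3 (0.04 log units; within the scatter) and a 1.2-fold lower number from compound 2 to compound 3 (0.07 log units; within the scatter). Both the oxetan-3-yl group and the 2-hydroxy-2-methylpropyl group therefore left this assay essentially unchanged relative to hydrogen, and the entering group brings together a four-membered non-aromatic ring with a hetero atom and a hydroxy group, features already present separately in compound 1 and compound 2. No step beyond the scatter is expected in either direction. The estimated step is a 1.1-fold lower number from compound 3 to compound 4 (0.02 log units; within the scatter). Compound 4 is expected at 40 nM, with a range from 20 nM to 80 nM.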

Compound 4, half-maximal inhibitory concentration: 57 nM
Compound 4: middle estimate off by 1.4-fold (0.15 log units), on the low side; the range from low to high includes it.
By their numbers in this assay, from the lowest: compounds 1, 3, 2 and 4 (each within the scatter of the next).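

Hydrogen on the aromatic nitrogen can give way to (3-hydroxyoxetan-3-yl)methyl, which carries the four-membered non-aromatic ring and the hydroxy group in one substituent, with this assay showing a 1.4-fold higher number from compound 3 to compound 4 (0.13 log units; within the scatter) for that change. Among these compounds, the same holds against the two earlier substituents, with a 1.2-fold higher number from compound 2 to compound 4 (0.07 log units; within the scatter) and a 1.5-fold higher number from compound 1 to compound 4 (0.18 log units; within the scatter), so no step among hydrogen and the three groups at this position lies beyond the scatter. No supporting measurement is available to explain this result or connect it to any feature of these groups.

An amine, a carboxylic acid or a longer chain on this aromatic nitrogen could still show whether any group here gives a step beyond the scatter. Also open, going by these compounds, is whether the same holds when another group replaces the methyl group on the five-membered aromatic ring.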